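From 1H-indol-3-yl to 4-chlorophenyl on the shared core

The compounds below may be only part of what the source reports. "The series", "measured", "known", "first", "only" and "open" are said of these compounds alone.

In a functional assay on DU-145 cells (Homo sapiens) for inhibition, read by trypan blue exclusion, with a stated time of 96 h (on this read-out higher numbers stand for weaker inhibition of growth and lower numbers for stronger inhibition of growth), compound 1 (`Cc1ccc(S/C(=C/c2c[nH]c3ccccc23)C(=O)c2ccc(Br)cc2)cc1`) gives 10000 nM as its reading. Compound 3 (`O=C(/C(=C/c1ccc(Br)cc1)S(=O)(=O)Cc1ccc(I)cc1)c1ccc(I)cc1`) gives 20000 nM and so lies within the usual scatter of compound 1, which means repeated measurements could not separate the two. Compound 2 (`O=C(/C(=C\c1ccc([N+](=O)[O-])c(O)c1)SCc1ccc(Br)cc1)c1ccc(C(F)(F)F)cc1`) gives 1000 nM as a clearly lower number. Compound 1 therefore stands level with compound 3 at the weak end of this small set.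

Compound 4 (`Cc1ccc(S/C(=C/c2ccc(Cl)cc2)C(=O)c2ccc(Br)cc2)cc1`) keeps the rest of compound 1 but carries 4-chlorophenyl in place of 1H-indol-3-yl on a double-bonded chain carbon bound to a double-bonded chain carbon. For the measured compounds named here, no two measured compounds differ in one place only, so nothing here measures this change directly. Compound 2 and compound 3 both lack 1H-indol-3-yl and differ from compound 1 elsewhere too. Yet compound 2 reads 1000 nM while compound 3 reads 20000 nM on the same test, so the missing group alone settles little. Only a small move toward a lower number is expected, and the estimated 1.4-fold lower number from compound 1 to compound 4 (0.15 log units; within the scatter) stays within the scatter. For compound 4 the estimated value is 7000 nM with an expected range from 2000 nM to 20000 nM on this wide evidence.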

Compound 4, concentration for 50% growth inhibition: 10000 nM
The estimate for compound 4 lay 1.4-fold (0.15 log units) below the measured number; the measured number falls inside the stated range.
By their numbers in this assay, from the lowest: compound 2; then compounds 1, 4 and 3 (each within the scatter of the next).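

In this assay, placing 4-chlorophenyl where 1H-indol-3-yl stood, on a double-bonded chain carbon bound to a double-bonded chain carbon, leaves no change at the digits printed from compound 1 to compound 4 (within the scatter). For the compounds shown here, this is the first direct reading of a single change in this set, and it isolates one position in a way the earlier compounds, which differ in several places at once, could not. On this one pair, a group with a hydrogen-bond donor and a five-membered aromatic ring can give way to a group with neither, and the growth-inhibition reading stays within the usual scatter. No measured evidence is available to explain the steady reading.

Still open, going by these compounds, is how this position responds to a group of a different kind, such as an amine, a carboxylic acid or a longer chain. A single pair also cannot show whether 4-chlorophenyl and 1H-indol-3-yl would still read alike if the groups elsewhere on the shared core were different.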